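This account rests on a few compounds, and the source may have more. Where it says the series, first, only, none or still open, it means among the compounds named here.

Compound 1 `O=c1[nH]c(=O)n([C@H]2C[C@H](O)[C@@H](CO)O2)cc1C#CI`: >= 100 ug/mL
Compound 2 `CC(=O)OC[C@H]1O[C@@H](n2cc(C#CI)c(=O)[nH]c2=O)[C@@H](OC(C)=O)[C@@H]1OC(C)=O`: 40 ug/mL

Both were tested in an ADME assay on E6SM cells (Homo sapiens) for cytotoxicity; on this read-out lower numbers stand for higher toxicity in this test and higher numbers for lower toxicity in this test. The value of compound 1 is a limit of the assay rather than a number, so compound 1 stands at the limit of >= 100 ug/mL in this assay, at which 1 of the 2 values shown sits. Compound 2 sits at a lower number, meaning more toxicity in this test. For the measured compounds named here, compound 3 `C[Si](C)(C)C#Cc1cn([C@H]2C[C@H](O)[C@@H](CO)O2)c(=O)[nH]c1=O` has not yet been tested; it differs from compound 1 in one place: a group of 4 heavy atoms (3 carbon, 1 silicon; no ring) in place of one iodine atom, on a triple-bonded carbon No measured step between two compounds is available, so the effect of this change in this assay is unknown; a step no larger than the scatter is expected, in either direction. Compound 3 is therefore estimated at 100 ug/mL, between 25 ug/mL and 400 ug/mL. That means an expected step of a number no higher from compound 1 to compound 3 (the limit leaves the size open).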

Compound 3, minimum cytotoxic concentration: > 400 ug/mL
Compound 3 was reported as a limit; the forecaster's own chance of this, stated with the estimate: 60%; middle value at least 4.0-fold (0.60 log units) from the limit.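

For the compounds shown here, compound 1 and compound 3 both carry limits of the assay rather than numbers, and no step between them can be read. The compounds shown leave open how large the change in this assay is when the group of 4 heavy atoms replaces iodo.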